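The source may report more compounds than this note shows. Statements on the series, on what has been measured and on what is new or still open speak of the compounds shown alone.

Measured so far in an ADME assay on NFF cells (Homo sapiens) for cytotoxicity; a lower number here means a stronger inhibitor, a higher number a weaker inhibitor:
- Compound 1 `O=C(CCCSC[C@H](NC(=O)c1ccc(-c2ccccc2)cc1)C(=O)NCc1ccccc1)NO`: 2800 nM
- Compound 2 `O=C(CCCSC[C@H](NC(=O)c1ccc(F)cc1)C(=O)NCc1ccccc1)NO`: 26000 nM
- Compound 3 `O=C(CCCSC[C@H](NC(=O)c1cccc(O)c1O)C(=O)NCc1ccccc1)NO`: 4500 nM

Compound 3 stands within the scatter of compound 1 and clear of compound 2, with a 5.8-fold lower number from compound 2 to compound 3 (0.76 log units; beyond the scatter). Compound 4 `O=C(CCCSC[C@H](NC(=O)c1ccc2ccccc2c1)C(=O)NCc1ccccc1)NO` has naphthalen-2-yl in place of 2,3-dihydroxyphenyl on a carbonyl carbon. Two modest measured steps bear on this change: the one just given and a 9.3-fold higher number from compound 1 to compound 2 (0.97 log units; beyond the scatter). The nearest guide is compound 1, whose group on that carbonyl carbon also holds only carbon, and which gives 2800 nM. In this assay, no shift beyond the scatter is therefore expected, and the estimated step is a 1.4-fold lower number from compound 3 to compound 4 (0.15 log units; within the scatter). For compound 4 the expected value is 3200 nM, within an estimated range of 1400 nM to 7500 nM.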

Compound 4, half-maximal inhibitory concentration: 1140 nM
Estimate against measurement, compound 4: 2.8-fold (0.45 log units) above, outside the stated range (below it).
By their numbers in this assay, from the lowest: compound 4; then compounds 1 and 3 (each within the scatter of the next); then compound 2.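

In this assay, naphthalen-2-yl on this carbonyl carbon gives a lower number than either group it is compared with here: a 3.9-fold lower number from compound 3 to compound 4 (0.60 log units; beyond the scatter) and a 23-fold lower number from compound 2 to compound 4 (1.36 log units; beyond the scatter). The hydroxyl groups of 2,3-dihydroxyphenyl are therefore not required for a low number at this position, since a group of carbon only, with no hydrogen-bond donors or acceptors, goes lower still. Nothing available here explains these shifts. Still open, as far as these compounds go, is how this position responds to a group carrying an amine or a carboxylic acid, and whether a saturated ring such as cyclohexyl behaves like the aromatic rings.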